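The compounds below may be only part of what the source reports. "The series", "measured", "known", "first", "only" and "open" are said of these compounds alone.

In a functional assay on MCF7 cells (Homo sapiens) for antiproliferative activity, read by CellTiter-Glo, with a stated time of 5 days (a higher number here means a weaker inhibitor, a lower number a stronger inhibitor), compound 1 (`N#Cc1ccc(/C(=C(\c2ccc(/C=C/C(=O)O)cc2)c2ccc3scnc3c2)C2CCC2)c(Cl)c1`) gives 1.4 nM and compound 2 (`N#Cc1cc(Cl)ccc1/C(=C(\c1ccc(/C=C/C(=O)O)cc1)c1ccc2scnc2c1)C1CCC1`) gives 0.9 nM in the same read-out. Compound 3 (`O=C(O)/C=C/c1ccc(/C(=C(\c2ccc(C(F)(F)F)cc2Cl)C2CCC2)c2ccc3scnc3c2)cc1`) gives 2.6 nM and so lies within the scatter of compound 1 but beyond the scatter of compound 2.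

Among the compounds with values here, compound 4 (`O=C(O)/C=C/c1ccc(/C(=C(\c2ccc(C(F)(F)F)cc2Cl)C2CCC2)c2ccc(-c3cn[nH]c3)cc2)cc1`) departs from compound 3 by a single change (4-(1H-pyrazol-4-yl)phenyl in place of 1,3-benzothiazol-5-yl on a double-bonded chain carbon bound to an aromatic carbon and a double-bonded chain carbon) at a place none of the measured steps touches. Those steps all leave the 1,3-benzothiazol-5-yl in place: the first is a 1.6-fold lower number from compound 1 to compound 2 (0.19 log units; within the scatter) and the second is a 1.9-fold higher number from compound 1 to compound 3 (0.27 log units; within the scatter) with the third 2.9-fold higher number from compound 2 to compound 3 (0.46 log units; beyond the scatter) (all small). They show only how narrow the spread is among these three compounds. Within the data shown here, the data hold no step at the new place, so they give no direct guide to its size or direction. A step toward a higher number is tentatively expected, with wide uncertainty: the estimated move is a 2.3-fold higher number from compound 3 to compound 4 (0.36 log units; beyond the scatter) in this assay (an expectation only). The estimated value for compound 4 is 6 nM (expected range 1.5 nM to 25 nM).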

Compound 4, half-maximal inhibitory concentration: 16 nM
Compound 4: the middle estimate sits 2.7-fold (0.43 log units) below what was measured; the range from low to high includes it.
By their numbers in this assay, from the lowest: compounds 2, 1 and 3 (each within the scatter of the next, the first and the last beyond it); then compound 4.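

In this assay, the place on a double-bonded chain carbon bound to an aromatic carbon and a double-bonded chain carbon proves more sensitive than the aryl changes among compound 1, compound 2 and compound 3, with a 6.2-fold higher number from compound 3 to compound 4 (0.79 log units; beyond the scatter). The change replaces 1,3-benzothiazol-5-yl with the larger 4-(1H-pyrazol-4-yl)phenyl, removes the sulfur and adds a hydrogen-bond donor, yet compound 4 still gives 16 nM, so this place accepts the new group at a modest cost. Nothing on hand ties that cost to any one of these differences.

A single step cannot show whether the pyrazole or the loss of 1,3-benzothiazol-5-yl drives the shift, and a plain phenyl or a 1H-indazol-5-yl at this place would help separate the two. From the compounds shown here alone, it also remains open whether the same change would cost as much with the nitrile-bearing aryl groups of compound 1 and compound 2.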